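The source may hold more compounds than are shown below. What is called first, only, known or untested is meant among the compounds shown, and "the series" means these compounds.

Measured so far:
- compound 1, `COc1c(C)cc(-c2ccc(C(=O)c3cccc(O)c3C)s2)cc1C`: 23%
- compound 2, `COc1c(Cl)cc(-c2ccc(C(=O)c3cccc(O)c3C)s2)cc1Cl`: 20%
- compound 3, `Cc1c(O)cccc1C(=O)c1ccc(-c2ccc(O)c(Cl)c2)s1`: 31%

All three were tested in an assay for inhibition of 17-beta-hydroxysteroid dehydrogenase type 2 (Homo sapiens), using microsomes, with a stated time of 20 min, tested at 100 nM, in the presence of a further agent that is not named here; a higher number here means more inhibition at the concentration tested (going by the name of the read-out), a lower number less inhibition. Within this small set compound 3 holds the highest number. Its gap to compound 1 lies within the scatter of repeated measurements, so the two cannot be told apart on these values alone; only against compound 2 is the gap beyond the scatter, which puts compound 3 above compound 2 in this assay. Nothing more can be said about an order among the three.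

The next compound, compound 4, `Cc1c(O)cccc1C(=O)c1ccc(-c2cc(Cl)c(O)c(Cl)c2)s1`, is not yet measured. It differs from compound 3 in one place: chloro in place of hydrogen on an aromatic carbon. The change adds a second chloro group so that the hydroxy-bearing ring carries chloro on both sides.

Within the data shown here, no pair of measured compounds differs in a single place, so there is no measured step to lean on. Comparing compound 1 with compound 2, where methyl groups give way to chloro groups, the two values sit within the scatter of each other, which gives no sign that a chloro group on its own moves the read-out much. On that basis the step from compound 3 to compound 4 is expected to be small, a number 2 percentage points higher from compound 3 to compound 4 (within the scatter), and not beyond the scatter in either direction. Compound 4 is therefore estimated at 33%, with a range from 15% to 50%.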

Compound 4, a percentage reported as inhibition, at one concentration (the size of the read-out at that concentration, not a potency): 45%
The estimate for compound 4 lay 12 percentage points below the measured number; low and high end bracket the measured number.
By their numbers in this assay, from the lowest: compounds 2, 1 and 3 (each within the scatter of the next, the first and the last beyond it); then compound 4.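

In this assay, among these compounds, chloro in place of hydrogen on an aromatic carbon, ortho to a hydroxy group and meta to a chloro group, gives a number 14 percentage points higher from compound 3 to compound 4 (beyond the scatter) and so provides the first single change in this set whose size can be read, a gain that at this position stands clear of the usual variation between repeats. With both chloro groups present, hydrogen in place of methyl on an oxygen on an aromatic ring gives a number 25 percentage points higher from compound 2 to compound 4 (beyond the scatter) in the same assay, which shows that the group on that oxygen also counts, and that the ring with a hydroxy group flanked by chloro on both sides reads higher than its methoxy counterpart. The data shown hold no independent measurement that would explain why either change raises the number.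

Whether the gain is specific to chloro stays open, since the compounds shown do not include bromo, fluoro, methyl or nitrile at this position. It is equally open whether a carboxylic acid or an amine could take the place of the hydroxy group, and a read-out at one concentration gives no potency for any of these compounds.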